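From ethoxy to isopropoxy on a shared core

The source may report more compounds than this note shows. Statements on the series, on what has been measured and on what is new or still open speak of the compounds shown alone.

Compound 1 (`CCOc1cc(-c2ccccc2)nc2ccccc12`) gives > 10 ug/mL in a functional assay on A549 cells (Homo sapiens) for cytotoxicity (a higher number here means that more compound is needed for the effect, a lower number that less compound is needed), and this is a limit, not a number. Compound 2 (`c1ccc(COc2cc(-c3ccccc3)nc3ccccc23)cc1`) gives > 10 ug/mL and this too is a limit. For the measured compounds named here, all that has been measured so far therefore rests on the limit of > 10 ug/mL in this assay, at which 2 of the 2 values shown sit, as the only reading. Going by the values given here, the one measured step is a step that the two limits leave unreadable from compound 1 to compound 2 and it places phenyl in place of methyl on the chain of compound 1, with no size to carry over.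

Compound 3 (`CC(C)Oc1cc(-c2ccccc2)nc2ccccc12`) turns ethoxy to isopropoxy, with methyl in place of hydrogen on a saturated chain carbon bound to an oxygen on an aromatic ring and a saturated chain carbon here. With no readable step to draw on, no change beyond the scatter is expected in this assay in either direction. The expected result is a step that the limit leaves unreadable from compound 1 to compound 3 as an estimate only. Compound 3 is estimated at 20 ug/mL with 10 ug/mL to 40 ug/mL as its expected range.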

Compound 3, half-maximal effective concentration: > 10 ug/mL
Compound 3 gave a limit, no number; the forecaster's own chance of this, stated with the estimate: 85%; the middle value is on the limit's open side.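

In this assay compound 3 gives > 10 ug/mL, and this is a limit. For the compounds shown here, no step from compound 1 or compound 2 to compound 3 can be read. The compounds shown leave open whether changing the group on the oxygen alters the result at all, as all three rest on a single limit: the limit of > 10 ug/mL in this assay, at which 3 of the 3 values shown sit.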